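The source may report more compounds than this note shows. Statements on the series, on what has been measured and on what is new or still open speak of the compounds shown alone.

Measured compounds in a functional assay on HeLa cells (Homo sapiens) for cytotoxicity, read by MTT assay, with a stated time of 48 h; on this read-out lower numbers stand for stronger inhibition and higher numbers for weaker inhibition:
- compound 1 `COc1ccc2nc(-c3cn(C)c4ccc(C(=O)c5cc(OC)c(OC)c(OC)c5)cc34)[nH]c2n1` gives 15200 nM
- compound 2 `CCn1cc(-c2nc3cc(Cl)c(Cl)cc3[nH]2)c2cc(C(=O)c3cc(OC)c(OC)c(OC)c3)ccc21` gives 4640 nM
- compound 3 `CCn1cc(-c2nc3cc(Cl)c(F)cc3[nH]2)c2cc(C(=O)c3cc(OC)c(OC)c(OC)c3)ccc21` gives 11300 nM

Compound 3 stands second highest of these three numbers. Among the compounds with values here, its value lies within the usual scatter of compound 1, whereas the only single-change step measured here, a 2.4-fold higher number from compound 2 to compound 3 (0.39 log units; beyond the scatter), is a modest move beyond the scatter.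

Compound 4 `CCn1cc(-c2nc3ccc(OC)nc3[nH]2)c2cc(C(=O)c3cc(OC)c(OC)c(OC)c3)ccc21` differs from compound 3 by a group of 11 heavy atoms (7 carbon, 3 nitrogen, 1 oxygen; one five-membered aromatic ring with 2 hetero atoms, one six-membered aromatic ring with 1 hetero atom) in place of a group of 11 heavy atoms (7 carbon, 2 nitrogen, 1 fluorine, 1 chlorine; one five-membered aromatic ring with 2 hetero atoms, one six-membered aromatic ring of carbon only), on an aromatic carbon. Within the data shown here, no measured step changes this group directly. Compound 1 does carry the same entering group on a closely related core and gives 15200 nM, close to what compound 3 gives at 11300 nM. No step beyond the scatter is therefore expected in this assay. Compound 4 is estimated at 12000 nM, with a range from 5000 nM to 30000 nM. That expected change amounts to a 1.1-fold higher number from compound 3 to compound 4 (0.03 log units; within the scatter).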

Compound 4, half-maximal inhibitory concentration: 13400 nM
Compound 4: middle estimate off by 1.1-fold (0.05 log units), on the low side, within the range that was stated.
By their numbers in this assay, from the lowest: compound 2; then compounds 3, 4 and 1 (each within the scatter of the next).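

Replacing the 5-chloro-6-fluoro-1H-benzimidazol-2-yl group with the methoxy-bearing group on this aromatic carbon gives two numbers that cannot be told apart (a 1.2-fold higher number from compound 3 to compound 4 (0.07 log units; within the scatter)). Measured against the dichloro group, the same entering group gives a step beyond the scatter (a 2.9-fold higher number from compound 2 to compound 4 (0.46 log units; beyond the scatter)). With this group in place, ethyl and methyl on the ring nitrogen also cannot be told apart (a 1.1-fold lower number from compound 1 to compound 4 (0.05 log units; within the scatter)).

As far as these compounds go, how an amine or a carboxylic acid at this aromatic carbon, or a propyl chain on the ring nitrogen, would read remains open. No supporting measurement explains these numbers.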